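The source may report more compounds than this note shows. Statements on the series, on what has been measured and on what is new or still open speak of the compounds shown alone.

Measured so far:
- compound 1, `CC1(C)c2[nH]nc(NC(=O)c3ccccc3)c2CN1Cc1cccc(I)c1`: 1360 nM
- compound 2, `CC1(C)c2[nH]nc(NC(=O)c3ccccc3)c2CN1Cc1ccccc1F`: 450 nM
- compound 3, `CC1(C)c2[nH]nc(NC(=O)c3ccccc3)c2CN1Cc1cc(F)cc(F)c1`: 190 nM

All three were tested in an assay on Sf21 cells for inhibition of high affinity nerve growth factor receptor (Homo sapiens), read by HTRF, with a stated time of 30 min, in the presence of a further agent that is not named here; a lower number here means a stronger inhibitor, a higher number a weaker inhibitor. Compound 3 gives the lowest of the three numbers: the step of a 2.4-fold lower number from compound 2 to compound 3 (0.37 log units; beyond the scatter) and the step of a 7.2-fold lower number from compound 1 to compound 3 (0.85 log units; beyond the scatter) both lie beyond the scatter, so compound 3 is the strongest inhibitor of the set. The step of a 3.0-fold lower number from compound 1 to compound 2 (0.48 log units; beyond the scatter) shows that a 2-fluorophenyl group already does better than the 3-iodophenyl group.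

Compound 4, `CC1(C)c2[nH]nc(NC(=O)c3ccccc3)c2CN1Cc1ccc(F)cc1F`, keeps everything except the group on the benzylic carbon, where (2,4-difluorophenyl in place of 3,5-difluorophenyl on a saturated chain carbon bound to an amine nitrogen in a ring). Going by the values given here, no measured pair shows exactly this rearrangement of the two fluorines. The nearest guide is compound 2, whose single fluorine on the ring gave 450 nM, a weaker number than compound 3. Compound 4 is therefore expected to fall between the two, with the step of a 1.7-fold higher number from compound 3 to compound 4 (0.23 log units; within the scatter) anticipated to be small and toward a higher number. The estimate for compound 4 is 320 nM, with a range of 120 nM to 850 nM.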

Compound 4, half-maximal inhibitory concentration: 2320 nM
Compound 4: middle estimate off by 7.3-fold (0.86 log units), on the low side, outside the stated range (above it).
By their numbers in this assay, from the lowest: compound 3; then compound 2; then compounds 1 and 4 (each within the scatter of the next).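

In this assay, going by these compounds alone, where the two fluorines stand on the benzyl group matters more than the earlier compounds could show: with the same atoms joined differently, 3,5-difluorobenzyl giving way to 2,4-difluorobenzyl brings a 12-fold higher number from compound 3 to compound 4 (1.09 log units; beyond the scatter) and is the largest step in the set. A further fluoro on the ring of compound 2 does not lower the number but gives a 5.2-fold higher number from compound 2 to compound 4 (0.71 log units; beyond the scatter), so adding fluoro at this position does not by itself improve inhibition. The 2,4-difluorophenyl group also gives no measurable gain over 3-iodophenyl, with a 1.7-fold higher number from compound 1 to compound 4 (0.23 log units; within the scatter), and nothing available here accounts for these differences.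

On these data alone, whether chloro or methoxy in place of the two fluoro groups of compound 3 would keep its number remains open. So does the effect of a pyridine ring in place of the phenyl ring.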